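The source may hold more compounds than are shown below. What is called first, only, known or untested is meant among the compounds shown, and "the series" means these compounds.

Measured so far in a functional assay on SW480 cells (Homo sapiens) for antiproliferative activity, read by sulforhodamine B assay, with a stated time of 48 h (a lower number here means a stronger inhibitor, a higher number a weaker inhibitor), for three compounds:
compound 1 `COc1cccc(/C=C/C(=O)/C=C(O)/C=C/c2cccc(OC)c2OC)c1OC` gives 12100 nM
compound 2 `COc1ccc(C=C(C(=O)/C=C/c2cccc(OC)c2OC)C(=O)/C=C/c2cccc(OC)c2OC)cc1OC` gives 410 nM
compound 3 `COc1ccc(/C=C/C(=O)C(=Cc2ccc(O)c(OC)c2)C(=O)/C=C/c2ccc(OC)cc2OC)c(OC)c1` gives 1520 nM

Compound 3 (1520 nM) holds the middle place of the three numbers, higher than compound 2 and lower than compound 1, with both gaps beyond the scatter. Next comes compound 4 `COc1ccc(/C=C/C(=O)C(=Cc2ccc(OC)c(O)c2)C(=O)/C=C/c2ccc(OC)cc2OC)c(OC)c1` with 3-hydroxy-4-methoxyphenyl in place of 4-hydroxy-3-methoxyphenyl on a double-bonded chain carbon bound to a double-bonded chain carbon as the counted difference. Within the data shown here, no measured pair isolates this swap, so the data offer no direct guide. The expected outcome in this assay is no step beyond the scatter, with a slight lean toward a lower number. The estimated change is a 1.3-fold lower number from compound 3 to compound 4 (0.10 log units; within the scatter) and would stay within the scatter. For compound 4 the estimated value is 1200 nM with 500 nM to 2800 nM as the expected range.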

Compound 4, half-maximal inhibitory concentration: 1370 nM
Compound 4: the middle estimate sits 1.1-fold (0.06 log units) below what was measured; the measured number falls inside the stated range.
By their numbers in this assay, from the lowest: compound 2; then compounds 4 and 3 (each within the scatter of the next); then compound 1.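

With 3-hydroxy-4-methoxyphenyl in place of 4-hydroxy-3-methoxyphenyl on a double-bonded chain carbon bound to a double-bonded chain carbon, this assay gives a 1.1-fold lower number from compound 3 to compound 4 (0.05 log units; within the scatter). This first one-place pair shows that, on this core, the two arrangements of hydroxy and methoxy at this position cannot be told apart in this read-out. Nothing on hand explains this result.

Still open, from the compounds shown here alone, is whether a different group at this position, such as an amine or a carboxylic acid, would give a step beyond the scatter.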